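From 2-fluorobenzyl to 2-chlorobenzyl: working notes

This account rests on a few compounds, and the source may have more. Where it says the series, first, only, none or still open, it means among the compounds named here.

Measured so far in a functional assay on MDA-MB-231 cells (Homo sapiens) for cytotoxicity, read by MTT assay, with a stated time of 24 h; a lower number here means a stronger inhibitor, a higher number a weaker inhibitor
- compound 1 `Cc1ccc(/C=C2\CN(C(=S)SCc3cn(Cc4ccc(F)cc4)nn3)C/C(=C\c3ccc(C)cc3)C2=O)cc1` gives 45600 nM
- compound 2 `Cc1ccc(/C=C2\CN(C(=S)SCc3cn(Cc4cccc(Cl)c4)nn3)C/C(=C\c3ccc(C)cc3)C2=O)cc1` gives 83000 nM
- compound 3 `Cc1ccc(/C=C2\CN(C(=S)SCc3cn(Cc4ccccc4F)nn3)C/C(=C\c3ccc(C)cc3)C2=O)cc1` gives 91500 nM

The three compounds share one core and differ only in the halogen-bearing phenyl group. Compound 3, with its 2-fluorophenyl group, stands within the scatter of both other compounds (a 2.0-fold higher number from compound 1 to compound 3 (0.30 log units; within the scatter)) and (a 1.1-fold higher number from compound 2 to compound 3 (0.04 log units; within the scatter)). The remaining pair is also not separated (a 1.8-fold higher number from compound 1 to compound 2 (0.26 log units; within the scatter)).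

Compound 4 `Cc1ccc(/C=C2\CN(C(=S)SCc3cn(Cc4ccccc4Cl)nn3)C/C(=C\c3ccc(C)cc3)C2=O)cc1` awaits measurement. It has chloro in place of fluoro on an aromatic carbon, ortho to a large group (chloro in place of fluoro on an aromatic carbon).

Within the data shown here, no measured step makes this exact exchange. The closest evidence is the set of three steps above, which exchange one halogen-bearing phenyl group for another, and none of them leaves the scatter. Compound 2 shows that a chloro-bearing member can sit level with compound 3 (a 1.1-fold higher number from compound 2 to compound 3 (0.04 log units; within the scatter)). Among the measured compounds shown here, with only three compounds, this is thin support.

No step beyond the scatter is therefore expected in this assay, and no firm direction can be claimed. The expected outcome is a 1.1-fold lower number from compound 3 to compound 4 (0.06 log units; within the scatter) and would need measurement to confirm. For compound 4 the estimated value is 80000 nM (expected range 42000 nM to 150000 nM).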

Compound 4, half-maximal inhibitory concentration: 93200 nM
Compound 4: the middle estimate sits 1.2-fold (0.07 log units) below what was measured; measured number inside the range.
By their numbers in this assay, from the lowest: compounds 1, 2, 3 and 4 (each within the scatter of the next, the first and the last beyond it).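

On an aromatic carbon ortho to a large group, the direct exchange of fluoro for chloro now has a measured step in this assay: a 1.0-fold higher number from compound 3 to compound 4 (0.01 log units; within the scatter), so this position shows no separation between the two halogens. Moving the chloro group gives a 1.1-fold higher number from compound 2 to compound 4 (0.05 log units; within the scatter) and adds no separation either, whereas a 2.0-fold higher number from compound 1 to compound 4 (0.31 log units; beyond the scatter) is the only step in the series beyond the scatter; it is modest and marginal, since a 2.0-fold higher number from compound 1 to compound 3 (0.30 log units; within the scatter) remains within the scatter. No measured evidence is available to explain these results.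

The compounds shown leave open whether bromo, methoxy, an amine or a carboxylic acid on an aromatic carbon ortho to a large group would give a step beyond the scatter from compound 3 or compound 4. They also leave open whether the fluoro-to-chloro exchange would remain within the scatter on any core other than the shared one, or in any cell line other than the one tested here.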